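Swapping a Cyclohexyl Ether for a Pyridinylmethyl Ether

This account rests on a few compounds, and the source may have more. Where it says the series, first, only, none or still open, it means among the compounds named here.

Measured compounds:
- compound 1 `CC(C(=O)NCc1ccc(C(F)(F)Cl)nc1N1CCN(c2ccccc2)CC1)c1ccc(NS(C)(=O)=O)c(F)c1`: 0.8 nM
- compound 2 `CC(C(=O)NCc1ccc(C(F)(F)Cl)nc1OC1CCCCC1)c1ccc(NS(C)(=O)=O)c(F)c1`: 0.9 nM

In an assay on CHO cells for antagonist activity at transient receptor potential cation channel subfamily V member 1 (Homo sapiens), read by FLIPR (on this read-out lower numbers stand for stronger inhibition and higher numbers for weaker inhibition), compound 1 gives 0.8 nM and compound 2 gives 0.9 nM. Compound 2 holds the higher of the two numbers, but the gap to compound 1, a 1.1-fold higher number from compound 1 to compound 2 (0.05 log units; within the scatter), lies within the scatter, so the two cannot be told apart. Compound 3 `CC(C(=O)NCc1ccc(C(F)(F)Cl)nc1OCc1ccccn1)c1ccc(NS(C)(=O)=O)c(F)c1` has not yet been measured. It differs from compound 2 by (pyridin-2-yl)methyl in place of cyclohexyl on an oxygen on an aromatic ring. Going by the values given here, the only measured step, from compound 1 to compound 2, changed the group on the aromatic carbon, while this step alters the group on the oxygen; that earlier step was within the scatter. Among the compounds with values here, with no step of this kind measured, only a modest change, if any, is expected in this assay for compound 3. The expected step is a 1.7-fold higher number from compound 2 to compound 3 (0.22 log units; within the scatter). The estimate for compound 3 is 1.5 nM, with a likely range from 0.5 nM to 5 nM.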

Compound 3, inhibition constant: 4.2 nM
Estimate against measurement, compound 3: 2.8-fold (0.45 log units) below; measured number inside the range.
By their numbers in this assay, from the lowest: compounds 1 and 2 (each within the scatter of the next); then compound 3.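

Going by these compounds alone, the group on the oxygen is not interchangeable: in this assay, (pyridin-2-yl)methyl in place of cyclohexyl gives a clear loss of strength (a 4.7-fold higher number from compound 2 to compound 3 (0.67 log units; beyond the scatter)), whereas the only earlier step showed no separable change (a 1.1-fold higher number from compound 1 to compound 2 (0.05 log units; within the scatter)). The new group also falls behind the 4-phenylpiperazin-1-yl group of compound 1 (a 5.3-fold higher number from compound 1 to compound 3 (0.72 log units; beyond the scatter)), so this position does not accept all large groups equally. No measurement at hand gives a reason for this shift.

Compound 3 differs from compound 2 in two ways at once, with an aromatic ring containing nitrogen and an added carbon link, and the compounds shown cannot separate these two changes. A benzyl group or a cyclohexylmethyl group on the same oxygen would show which of the two matters.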